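The source may hold more compounds than are shown below. What is called first, only, known or untested is meant among the compounds shown, and "the series" means these compounds.

Measured so far in an ADME assay on microsomes from liver (Rattus norvegicus) for metabolic stability; a higher number here means that the compound lasts longer, a lower number that the compound disappears faster:
compound 1, `N#Cc1ccc(-c2nc(NCCNc3ccc([N+](=O)[O-])c(N)n3)ncc2-c2ncc[nH]2)cc1`: > 0.5 h.
compound 2, `Nc1nc(NCCNc2ncc(-c3ncc[nH]3)c(-c3ccc(Cl)cc3)n2)ccc1[N+](=O)[O-]`: > 0.5 h.
compound 3, `Nc1nc(NCCNc2ncc(-c3ncc[nH]3)c(-c3ccc(Cl)cc3F)n2)ccc1[N+](=O)[O-]`: > 0.5 h.

The value of compound 1 is a limit of the assay, not a number. Compound 2 likewise stands at a limit. Compound 3 stands at a limit as well. The change to compound 4, `Nc1nc(NCCNc2ncc(-c3ncc[nH]3)c(-c3ccc(Cl)cc3Br)n2)ccc1[N+](=O)[O-]`, is 2-bromo-4-chlorophenyl in place of 4-cyanophenyl on an aromatic carbon. The measured steps that bear on it are a step that the two limits leave unreadable from compound 1 to compound 2 and a step that the two limits leave unreadable from compound 1 to compound 3, which alter the same phenyl group, and a step that the two limits leave unreadable from compound 2 to compound 3, which adds a halogen to it; none has a readable size because of the limit of > 0.5 h in this assay, at which 3 of the 3 values shown sit. No step beyond the scatter can therefore be read from them. Compound 4 is expected to remain at that limit in this assay, so the expected step is a step that the limit leaves unreadable from compound 1 to compound 4. Compound 4 is estimated at 0.8 h, with a range from 0.5 h to 2 h.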

Compound 4, half-life: > 0.5 h
Compound 4: no number, only a limit; the forecaster's own chance of this, stated with the estimate: 85%; the middle value does not contradict the limit.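

Going by these compounds alone, compound 4 also returns only a limit in this assay, so no step to it from compound 1, compound 2 or compound 3 can be read: the limit of > 0.5 h in this assay, at which 4 of the 4 values shown sit. The compounds shown leave open the actual half-life of each compound and whether any of these phenyl changes alters it.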